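Sulfide to Sulfone at the Pyridine Side Chain

This account rests on a few compounds, and the source may have more. Where it says the series, first, only, none or still open, it means among the compounds named here.

This account concerns a pair of amides built on a shared core. Compound 1 `CC(C)CCSc1nc(C(F)(F)F)ccc1CNC(=O)C(C)c1ccc(NS(C)(=O)=O)c(F)c1` gives 0.7 nM in an assay on CHO-K1 cells for antagonist activity at transient receptor potential cation channel subfamily V member 1 (Homo sapiens), read by FLIPR; a lower number here means a stronger inhibitor, a higher number a weaker inhibitor. Among the measured compounds shown here, compound 2 `CC(C(=O)NCc1ccc(C(F)(F)F)nc1SCCCN1CCCCC1)c1ccc(NS(C)(=O)=O)c(F)c1` gives 3 nM in the same assay, which is the highest of the two numbers measured so far; its nearest neighbour is compound 1, and the step of a 4.3-fold higher number from compound 1 to compound 2 (0.63 log units; beyond the scatter) is modest but lies beyond the scatter.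

Compound 3 `CC(C(=O)NCc1ccc(C(F)(F)F)nc1S(=O)(=O)C1CCCCC1)c1ccc(NS(C)(=O)=O)c(F)c1` differs from compound 2 in one place: cyclohexylsulfonyl in place of (3-(piperidin-1-yl)propyl)sulfanyl on an aromatic carbon. For the measured compounds named here, only one measured step touches this part of the molecule, a 4.3-fold higher number from compound 1 to compound 2 (0.63 log units; beyond the scatter), and it altered the far end of the chain rather than the sulfur itself, so it offers limited guidance. Going by the values given here, no measured pair shows a sulfanyl group exchanged for a sulfonyl group, nor the loss of the chain for a ring directly on sulfur. The author therefore expects a step of at most modest size for compound 3, with direction uncertain, leaning slightly toward a higher number, as a 1.7-fold higher number from compound 2 to compound 3 (0.22 log units; within the scatter) states. Compound 3 is expected to give about 5 nM, within a range from 1 nM to 30 nM.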

Compound 3, inhibition constant: "not active" (no number reported)
Compound 3 has no reported number here; the estimate stays without a comparison.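

In this assay, among the compounds shown here, compound 3 is reported only as "not active", with no number, so no step from compound 2 to compound 3 can be read. The compounds shown leave open how far cyclohexylsulfonyl in place of (3-(piperidin-1-yl)propyl)sulfanyl shifts the inhibition constant. No measured evidence bears on this result.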